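From compound 3 to compound 4: one more nitrogen group

This account rests on a few compounds, and the source may have more. Where it says the series, first, only, none or still open, it means among the compounds named here.

In an ADME assay on microsomes from liver (Rattus norvegicus) for metabolic stability, read by LC-MS, using NADPH, with a stated time of 10 min, tested at 0.1 uM (on this read-out higher numbers stand for fast clearance and lower numbers for slow clearance), compound 1 `O=C(NCCCCc1ccccc1)c1cccc(C2SCC(=O)N2c2ccccn2)c1` gives 1480 mL.min-1.g-1, compound 2 `C#Cc1cccc(N2C(=O)CSC2c2cccc(C(=O)NCCCCc3ccccc3)c2)c1` gives 1820 mL.min-1.g-1 and compound 3 `CC(F)(F)c1cccc(N2C(=O)CSC2c2cccc(C(=O)NCCCCc3ccccc3)c2)c1` gives 2320 mL.min-1.g-1. Compound 3 therefore stands within the usual scatter of both others, with a 1.6-fold higher number from compound 1 to compound 3 (0.20 log units; within the scatter) and a 1.3-fold higher number from compound 2 to compound 3 (0.11 log units; within the scatter). The next compound, compound 4 `O=C(NCCCCc1ccccc1)c1cccc(C2SCC(=O)N2c2ccc(C3CC3)cc2)c1`, carries a group of 9 heavy atoms (9 carbon; one three-membered non-aromatic ring of carbon only, one six-membered aromatic ring of carbon only) in place of a group of 10 heavy atoms (8 carbon, 2 fluorine; one six-membered aromatic ring of carbon only), on an amide-type nitrogen in a ring. Exchanges at this same place have so far stayed small, as compound 2 shows with a 1.2-fold higher number from compound 1 to compound 2 (0.09 log units; within the scatter), and compound 3 shows the same with the two steps above. No step beyond the scatter is therefore expected in this assay, and the estimate is a 1.1-fold lower number from compound 3 to compound 4 (0.04 log units; within the scatter). For compound 4 the expected value is 2100 mL.min-1.g-1, within an estimated range from 1200 mL.min-1.g-1 to 3600 mL.min-1.g-1.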

Compound 4, intrinsic clearance in microsomes in the Rattus norvegicus assay: 2280 mL.min-1.g-1
For compound 4 the middle estimate is 1.1-fold (0.04 log units) below the measured one, within the range that was stated.
By their numbers in the Rattus norvegicus assay, from the lowest: compounds 1, 2, 4 and 3 (each within the scatter of the next).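

In the Rattus norvegicus assay compound 4 gives 2280 mL.min-1.g-1, and 4-cyclopropylphenyl on the amide-type nitrogen in a ring brings a three-membered non-aromatic ring to this place, yet every step stays small: a 1.0-fold lower number from compound 3 to compound 4 (0.01 log units; within the scatter), a 1.3-fold higher number from compound 2 to compound 4 (0.10 log units; within the scatter) and a 1.5-fold higher number from compound 1 to compound 4 (0.19 log units; within the scatter). Within the data shown here, in a physicochemical assay for solubility, read by turbidimetry, measured as kinetic solubility, at pH 7.4 (a lower number here means a less soluble compound, a higher number a more soluble compound), compound 3 gives 2000 nM and compound 4 gives 2000 nM, and the same exchange shows no change at the digits printed from compound 3 to compound 4 (within the scatter), the first reading of this place in that assay. No experimental evidence is available to explain either result.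

On these data alone, whether an amine or a carboxylic acid on the aromatic ring at this place would give a step beyond the scatter in either assay remains open.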